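The compounds below may be only part of what the source reports. "The series", "measured", "known", "first", "only" and "open" are said of these compounds alone.

Of the compounds shown here, two sharing one core have been measured in a physicochemical assay for lipophilicity; on this read-out lower numbers stand for lower lipophilicity and higher numbers for higher lipophilicity. Compound 1 `C[C@H]1CC[C@@H]2[C@@H](OC(=O)[C@]23CC(c2ccccc2Br)=NO3)[C@]2(C)C(=O)C=C[C@@]12O` gives 2.22, and compound 2 `C[C@H]1CC[C@@H]2[C@@H](OC(=O)[C@]23CC(c2ccc(N(C)C)cc2)=NO3)[C@]2(C)C(=O)C=C[C@@]12O` gives 1.51, the lower of the two numbers. Compound 3 `C[C@H]1CC[C@@H]2[C@@H](OC(=O)[C@]23CC(c2ccc(O)cc2)=NO3)[C@]2(C)C(=O)C=C[C@@]12O` has not yet been measured. It differs from compound 2 at a single place, with hydroxy in place of dimethylamino on an aromatic carbon. Within the data shown here, no measured step swaps these two groups directly. Among the measured compounds shown here, the only measured step, which changes the group on the carbon with a double bond to nitrogen, is a number 0.71 log units lower from compound 1 to compound 2 (beyond the scatter), and it is the sole guide, pointing to a modest move toward a lower number. The expected change is a number 0.41 log units lower from compound 2 to compound 3 (beyond the scatter). In this assay, compound 3 is therefore estimated at 1.1, with an expected range from 0.65 to 1.55.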

Compound 3, partition coefficient: 0.932
Estimate against measurement, compound 3: 0.17 log units above; the range from low to high includes it.
By their numbers in this assay, from the lowest: compound 3; then compound 2; then compound 1.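

In this assay, hydroxy in place of dimethylamino on the aromatic carbon para to a large group gives a number 0.58 log units lower from compound 2 to compound 3 (beyond the scatter) and so shows that the read-out responds to the group at this one place, with the rest of the structure unchanged. The earlier compounds shown here showed only a change of the whole aromatic group, whereas this step isolates a single substituent. Against the bromine-bearing compound, 4-hydroxyphenyl in place of 2-bromophenyl gives a number 1.29 log units lower from compound 1 to compound 3 (beyond the scatter) and is the widest gap among the three compounds.

On these data alone, whether methoxy or a plain amino group at the same place would read closer to hydroxy or to dimethylamino remains open. No evidence at hand bears on why the number moves with these changes.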